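Cytotoxicity notes on a diketopiperazine-like series, compound 4 pending

A few compounds are considered here, and "the series" means these few. Any claim that something is new, unique, unknown or untested is made for them only; others in the source may bear on it.

Measured compounds:
- compound 1, `C=CCn1c(=O)/c(=C\c2cccc(Br)c2)[nH]c(=O)/c1=C\c1ccccc1OC`: 2300 nM
- compound 2, `C=CCn1c(=O)/c(=C\c2cccc(Br)c2)[nH]c(=O)/c1=C\c1cccc(Br)c1`: "not active" (no number reported)
- compound 3, `COc1ccccc1/C=c1/[nH]c(=O)/c(=C\c2cccc(Cl)c2Cl)[nH]c1=O`: "not active" (no number reported)

For the measured compounds named here, in a functional assay on Huh-7 cells (Homo sapiens) for cytotoxicity, read by CCK-8 assay, with a stated time of 72 h (a lower number here means a stronger inhibitor, a higher number a weaker inhibitor), compound 1 gives 2300 nM, the only number in the set. Compound 2 is reported in this assay as "not active" (no number reported) without a number, and compound 3 likewise as "not active" (no number reported) without a number, so neither can be placed on a scale against compound 1. Going by the values given here, no step between two numbered compounds exists here.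

Compound 4, `C=CCn1c(=O)/c(=C\c2ccccc2Cl)[nH]c(=O)/c1=C\c1ccccc1OC`, is the next entry to be measured. Relative to compound 1 the change is 2-chlorophenyl in place of 3-bromophenyl on a double-bonded chain carbon bound to an aromatic carbon. Among the compounds with values here, with only one number in hand and the two other entries inactive, there is no measured step to lean on. The expectation for compound 4 in this assay is a small shift, if any, toward weaker inhibition, estimated as a 1.5-fold higher number from compound 1 to compound 4 (0.18 log units; within the scatter). The estimate for compound 4 is 3500 nM, with a range from 1000 nM to 15000 nM, and a real chance that only an inactive call is returned.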

Compound 4, half-maximal inhibitory concentration: 6400 nM
For compound 4 the middle estimate is 1.8-fold (0.26 log units) below the measured one, within the range that was stated.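

In this assay, for the compounds shown here, 2-chlorophenyl in place of 3-bromophenyl on a double-bonded chain carbon bound to an aromatic carbon gives a 2.8-fold higher number from compound 1 to compound 4 (0.44 log units; beyond the scatter), the first readable step. This position therefore responds to the aryl group it carries, though modestly: the number shifts toward weaker inhibition, yet compound 4 still gives a measurable value with the rest of compound 1 unchanged. No measured evidence bears on why the number moves with this change.

The step changes the halogen and its place on the ring at once, so this single pair does not separate the two, and 3-chlorophenyl or 2-bromophenyl would be needed to do so. As far as these compounds go, how an aryl group carrying an amine or a carboxylic acid would read at this carbon also remains open.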